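The compounds below may be only part of what the source reports. "The series", "measured", "known", "first", "only" and "open" are said of these compounds alone.

Compound 1 `Cn1c(Cc2nn(C)c(=O)c3ccccc23)nnc1SCCCCCCCCCCC(=O)Nc1ccc(Cl)cc1Cl` is the weaker of the two compounds measured in an assay on isolated protein (Mus musculus) for inhibition of IL15-IL15 receptor (Homo sapiens), read by resazurin assay, with stated times of 30 min and 2.5 days (a higher number here means a weaker inhibitor, a lower number a stronger inhibitor), where compound 1 gives 3300 nM. Its only companion, compound 2 `Cn1c(Cc2nn(C)c(=O)c3ccccc23)nnc1S(=O)(=O)CCCCCCCC(=O)Nc1ccc(Br)cc1Br`, reaches 1400 nM in this assay, and the gap between the two lies beyond the usual scatter, so compound 1 stands clearly at the weaker end of what has been measured.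

Compound 3 `Cn1c(Cc2nn(C)c(=O)c3ccccc23)nnc1SCCCCCCCCCCC(=O)Oc1ccc(Cl)cc1Cl` has not yet been measured. It differs from compound 1 in one place: 2,4-dichlorophenoxy in place of (2,4-dichlorophenyl)amino on a carbonyl carbon. Among the measured compounds shown here, no other pair of measured compounds shows this change, so nothing measured here says how large the step will be. With the single-point change at the carbonyl carbon, a step no larger than the scatter, or a modest weakening, is expected, which is the meaning of a 1.5-fold higher number from compound 1 to compound 3 (0.18 log units; within the scatter). Compound 3 is therefore estimated to reach 5000 nM in this assay, within a range from 1500 nM to 20000 nM.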

Compound 3, half-maximal inhibitory concentration: 8700 nM
Beside the measured number, compound 3's estimate is 1.7-fold (0.24 log units) below it; the range from low to high includes it.
By their numbers in this assay, from the lowest: compound 2; then compound 1; then compound 3.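

In this assay the exchange of (2,4-dichlorophenyl)amino for 2,4-dichlorophenoxy on the carbonyl carbon gives a 2.6-fold higher number from compound 1 to compound 3 (0.42 log units; beyond the scatter) and is the only single-place step among the compounds shown. It shows that this position is sensitive to the atom linking the carbonyl carbon to the dichlorinated ring: with the heavy-atom count unchanged, the swap of nitrogen for oxygen removes the amide hydrogen as a hydrogen-bond donor, adds a hydrogen-bond acceptor, and leaves a weaker inhibitor. No available evidence bears on the cause of this step.

A single pair cannot separate the lost donor from the gained acceptor, nor show whether the step would carry over to other chain lengths. A (2,4-dichlorophenyl)methylamino group on the same carbonyl carbon, which also lacks the amide hydrogen, would leave the nitrogen in place and so remains an open comparison.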